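Carbamoyl in place of triazolyl on the shared core

A few compounds are considered here, and "the series" means these few. Any claim that something is new, unique, unknown or untested is made for them only; others in the source may bear on it.

Compound 1 `CC(C)C(Cc1nnc[nH]1)c1ccc(-c2ccc3cccc(F)c3c2)[nH]c1=O`: 0.307 h
Compound 2 `CCC(CC)(c1nnc[nH]1)c1ccc(-c2ccc3cccc(F)c3c2)[nH]c1=O`: 1.19 h

Within the data shown here, in an ADME assay on microsomes from liver (Homo sapiens) for metabolic stability (a higher number here means that the compound lasts longer, a lower number that the compound disappears faster), compound 1 gives 0.307 h, the lower of the two numbers measured so far, while compound 2 gives 1.19 h, which lies beyond the scatter above it. Compound 3 `CC(C)C(CC(N)=O)c1ccc(-c2ccc3cccc(F)c3c2)[nH]c1=O` is not yet measured. Its difference from compound 1 is carbamoyl in place of 4H-1,2,4-triazol-3-yl on a saturated chain carbon, two bonds along the chain from an aromatic carbon. Among the measured compounds shown here, with no measured pair that isolates this change, the step from compound 1 to compound 3 is expected to be small, likely within the scatter, with a 1.1-fold higher number from compound 1 to compound 3 (0.06 log units; within the scatter). Compound 3 is therefore expected to give 0.35 h, in a range from 0.15 h to 0.8 h.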

Compound 3, half-life: < 0.0667 h
Compound 3: only a limit was reported; the forecaster's own chance of this, stated with the estimate: 5%; middle value at least 5.2-fold (0.71 log units) from the limit.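

In this assay, carbamoyl does not stand in for 4H-1,2,4-triazol-3-yl on this saturated chain carbon without cost: the exchange gives an at least 4.6-fold lower number from compound 1 to compound 3 (0.66 log units; beyond the scatter). Compound 3 gives < 0.0667 h, which is a limit of the assay and not a number. The step therefore has a bound rather than a full size: the limit of < 0.0667 h in this assay, at which 1 of the 3 values shown sits.

The compounds shown do not separate the effect of carbamoyl itself from that of removing the ring. On these data alone, how a carboxylic acid, a nitrile or a tetrazolyl group would behave at this place remains open.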